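Aryl exchange from a level pair: compound 1 to compound 3

The compounds below may be only part of what the source reports. "The series", "measured", "known", "first", "only" and "open" are said of these compounds alone.

In a functional assay on cells (Panel colon (Carcinoma cell lines), Homo sapiens) for inhibition, read by sulforhodamine B assay, with a stated time of 48 h (a lower number here means a stronger inhibitor of growth, a higher number a weaker inhibitor of growth), compound 1 `CN1CCN(CCCOc2cccc3nc(Nc4ccc(Cl)c(C(F)(F)F)c4)ccc23)CC1` gives 3170 nM. Among the measured compounds shown here, compound 2 `CN1CCN(CCCOc2cccc3nc(Nc4ccc(Cl)c(F)c4)ccc23)CC1` gives 3170 nM, so compound 1 stands level with its only measured neighbour. Compound 3 `CN1CCN(CCCOc2cccc3nc(Nc4ccc(F)c(F)c4)ccc23)CC1` has not yet been measured. The change is 3,4-difluorophenyl in place of 4-chloro-3-(trifluoromethyl)phenyl on a nitrogen on an aromatic ring.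

For the measured compounds named here, one measured step bears on this: no change at the digits printed from compound 1 to compound 2 (within the scatter), with fluoro in place of trifluoromethyl on an aromatic carbon. Going by the values given here, it covers only part of the change, and the rest has no measured counterpart. Resting on that single step, the expected result in this assay is no change at the digits printed from compound 1 to compound 3 (within the scatter), with no shift beyond the scatter expected in either direction. For compound 3 the estimate is 3170 nM, with an expected range of 1800 nM to 5600 nM.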

Compound 3, concentration for total growth inhibition: 5900 nM
Compound 3: middle estimate off by 1.9-fold (0.27 log units), on the low side; measured number above the stated range.
By their numbers in this assay, from the lowest: compounds 1, 2 and 3 (each within the scatter of the next).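

In this assay the exchange of the whole aryl group, 3,4-difluorophenyl in place of 4-chloro-3-(trifluoromethyl)phenyl on a nitrogen on an aromatic ring, gives a 1.9-fold higher number from compound 1 to compound 3 (0.27 log units; within the scatter) and so stays level even with both substituents replaced. Chloro is now varied for the first time: fluoro in place of chloro on an aromatic carbon gives a 1.9-fold higher number from compound 2 to compound 3 (0.27 log units; within the scatter) and so adds a second single-group exchange on this aryl ring that stays within the scatter. Nothing measured here offers a reason for this flat reading.

Among the compounds shown here, the series so far covers only chloro, fluoro and trifluoromethyl on the aryl group, in a single assay. Going by these compounds, whether the reading holds with a methoxy group, an amine or a carboxylic acid on that ring, or with an unsubstituted phenyl, remains open.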